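This account rests on a few compounds, and the source may have more. Where it says the series, first, only, none or still open, it means among the compounds named here.

Compound 2 `O=C(NCCCCc1ccccc1)c1cccc(C2SCC(=O)N2c2cccc(F)c2)c1` is the starting point, and compound 4 `COc1cc(F)ccc1N1C(=O)CSC1c1cccc(C(=O)NCCCCc2ccccc2)c1` the compound it leads to. In a functional assay on HOS cells (Homo sapiens) for inhibition, read by CCK-8 assay, with a stated time of 72 h, tested at 1 uM (a lower number here means less inhibition, a higher number more inhibition at the concentration tested (going by the name of the read-out)), compound 2 gives 84%, the highest of the three numbers shown, although compound 1 `COc1cccc(OC)c1N1C(=O)CSC1c1cccc(C(=O)NCCCCc2ccccc2)c1`, which gives 80%, lies within the scatter of it; compound 3 `COc1ccccc1N1C(=O)CSC1C(=O)NCCCCc1ccccc1` gives 0% and stands far lower. The change from compound 2 to compound 4 is 4-fluoro-2-methoxyphenyl in place of 3-fluorophenyl on an amide-type nitrogen in a ring. Among the measured compounds shown here, only one measured step touches the same place, the group on an amide-type nitrogen in a ring: it amounts to a number 4 percentage points higher from compound 1 to compound 2 (within the scatter), that is, exchanging 2,6-dimethoxyphenyl for 3-fluorophenyl there left the read-out unchanged. Going the other way with a group that carries both a methoxy and a fluorine is therefore expected to produce no step beyond the scatter in this assay, and the step from compound 2 to compound 4 is estimated as a number 4 percentage points lower from compound 2 to compound 4 (within the scatter). For compound 4 the expected value in this assay is 80%, with a range from 65% to 90%.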

Compound 4, a percentage reported as inhibition, at one concentration (the size of the read-out at that concentration, not a potency): 81%
Beside the measured number, compound 4's estimate is 1 percentage points below it; low and high end bracket the measured number.
By their numbers in this assay, from the lowest: compound 3; then compounds 1, 4 and 2 (each within the scatter of the next).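

In this assay, placing 4-fluoro-2-methoxyphenyl on the amide-type nitrogen in a ring gives a number 3 percentage points lower from compound 2 to compound 4 (within the scatter) and a number 1 percentage points higher from compound 1 to compound 4 (within the scatter). Among the compounds shown here, with this third group, the one measured step at this position becomes a small set: 3-fluorophenyl, 2,6-dimethoxyphenyl and 4-fluoro-2-methoxyphenyl all read alike here, and the group combining a methoxy and a fluorine on one ring behaves no differently from the groups carrying only one of these. The data offer no explanation for this sameness.

Still open, on these data alone, is whether the read-out would hold with a carboxylic acid or an amine on the phenyl ring, or with a plain ethyl chain in place of that ring. As far as these compounds go, each compound was read at a single concentration, so it also remains open whether compounds 1, 2 and 4 would show a stronger or weaker effect than one another at other concentrations.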